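Shortening a hydroxamate chain on two related cores

The source may report more compounds than this note shows. Statements on the series, on what has been measured and on what is new or still open speak of the compounds shown alone.

Of the compounds shown here, three have so far been tested in a functional assay on Hep 3B2 cells (Homo sapiens) for antiproliferative activity, read by sulforhodamine B assay, with a stated time of 48 h; on this read-out higher numbers stand for weaker inhibition of growth and lower numbers for stronger inhibition of growth. Compound 1 `CC(C)CCc1c(OCCCCCC(=O)NO)ccc2ccc(=O)oc12` gives 800 nM in this assay. Compound 3 `CC(C)CCc1c(OCCCCC(=O)NO)ccc2ccc(=O)oc12` differs from compound 1 by hydroxycarbamoyl in place of (hydroxycarbamoyl)methyl on a saturated chain carbon, four bonds along the chain from an oxygen on an aromatic ring; in this assay compound 3 gives 1310 nM. That change produced a step of a 1.6-fold higher number from compound 1 to compound 3 (0.21 log units; within the scatter). Compound 2 `CC(C)CCc1c(OCCCCCCC(=O)NO)ccc2c1OC(=O)CC2` carries a different core; the difference between the two cores is not broken down here. In this assay compound 2 reaches only > 30000 nM, which is a limit of the assay and not a number, matching (the limit of > 30000 nM in this assay, at which 1 of the 3 values shown sits). Compound 4 `CC(C)CCc1c(OCCCCCC(=O)NO)ccc2c1OC(=O)CC2` has not been measured; it differs from compound 2 by hydroxycarbamoyl in place of (hydroxycarbamoyl)methyl on a saturated chain carbon, five bonds along the chain from an oxygen on an aromatic ring. Among the compounds with values here, this is the same kind of change as the one from compound 1 to compound 3, but here the place is five bonds along the chain from an oxygen on an aromatic ring rather than four. For compound 4 a step that the limit leaves unreadable from compound 2 to compound 4 in this assay is expected, because a 1.6-fold higher number from compound 1 to compound 3 (0.21 log units; within the scatter) was small. Compound 2 stands at a limit. Compound 4 is therefore estimated at about 45000 nM, within a range from 15000 nM to 150000 nM, and will most likely again be reported only as a limit.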

Compound 4, concentration for 50% growth inhibition: > 30000 nM
Compound 4 ended at the assay's limit; the forecaster's own chance of this, stated with the estimate: 85%; the middle value is on the limit's open side.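

In this assay compound 4 gives > 30000 nM, which is a limit of the assay and not a number. Compound 2 sits at the same limit, so no step between compound 2 and compound 4 can be read: the limit of > 30000 nM in this assay, at which 2 of the 4 values shown sit.

The compounds shown leave open how strongly, if at all, compound 2 and compound 4 inhibit growth, and whether shortening the chain matters on their shared core.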